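The source may report more compounds than this note shows. Statements on the series, on what has been measured and on what is new or still open speak of the compounds shown alone.

Measured so far in a functional assay on MGC-803 cells (Homo sapiens) for inhibition, read by sulforhodamine B assay; a lower number here means a stronger inhibitor, a higher number a weaker inhibitor:
compound 1 `CCCc1ccc(NC2=CC(=O)c3c(nc4n3[C@H]3OC[C@@H](O)[C@H]3OC4)C2=O)cc1`, 1920 nM
compound 2 `COc1ccccc1NC1=CC(=O)c2c(nc3n2[C@H]2OC[C@@H](O)[C@H]2OC3)C1=O`, 1670 nM
compound 3 `O=C1C(Nc2ccc(C(F)(F)F)cc2)=CC(=O)c2c1nc1n2[C@H]2OC[C@@H](O)[C@H]2OC1`, 1860 nM

Compound 2 stands within the scatter of both of the others: a 1.1-fold lower number from compound 1 to compound 2 (0.06 log units; within the scatter) and a 1.1-fold higher number from compound 2 to compound 3 (0.05 log units; within the scatter), and likewise a 1.0-fold lower number from compound 1 to compound 3 (0.01 log units; within the scatter). Compound 4 `CCCN(CCC)C1=CC(=O)c2c(nc3n2[C@H]2OC[C@@H](O)[C@H]2OC3)C1=O` is not yet measured; it differs from compound 2 by dipropylamino in place of (2-methoxyphenyl)amino on a double-bonded ring carbon. Going by the values given here, none of the measured steps bears directly on this change: each of them exchanges one substituted aromatic ring for another on the amine nitrogen, and all stay within the scatter. Among the compounds with values here, no measured step removes the aromatic ring from the amine altogether, so the direction of the step is open and a step beyond the scatter cannot be ruled out either way. Compound 4 is therefore expected to give about 2500 nM, within a wide range from 700 nM to 9000 nM, which corresponds to an expected step of a 1.5-fold higher number from compound 2 to compound 4 (0.18 log units; within the scatter).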

Compound 4, half-maximal inhibitory concentration: > 16000 nM
Compound 4 was reported as a limit; the forecaster's own chance of this, stated with the estimate: 10%; middle value at least 6.4-fold (0.80 log units) from the limit.
By their numbers in this assay, from the lowest: compounds 2, 3 and 1 (each within the scatter of the next). At a limit, above all of these: compound 4.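

Going by these compounds alone, the earlier compounds changed only the aromatic ring on the amine nitrogen, and none of those steps left the scatter; this change removes that ring and the amine hydrogen together, and it gives the first step beyond the scatter at this position: an at least 9.5-fold higher number from compound 2 to compound 4 (0.98 log units; beyond the scatter). Compound 4 gives > 16000 nM, which is a limit of the assay and not a number: the limit of > 16000 nM in this assay, at which 1 of the 4 values shown sits.

The compounds shown cannot separate the loss of the ring from the loss of the amine hydrogen. Propylamino or methyl(phenyl)amino at this carbon would bear on that question, and their values remain open.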